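Swapping 4-methoxyphenyl for naphthalen-1-yl

The source may report more compounds than this note shows. Statements on the series, on what has been measured and on what is new or still open speak of the compounds shown alone.

Measured so far in a functional assay on HL-60 cells (Homo sapiens) for inhibition, read by CCK-8 assay, with a stated time of 48 h, tested at 20 uM; on this read-out lower numbers stand for less inhibition of growth and higher numbers for more inhibition of growth at the one concentration tested:
- compound 1 `Cc1ccc(S(=O)(=O)Oc2ccccc2/C=C(\C#N)C(=O)Nc2nnc(C)s2)cc1` gives 78%
- compound 2 `COc1ccc(Cc2nnc(NC(=O)/C(C#N)=C/c3ccccc3OS(=O)(=O)c3ccc(C)cc3)s2)cc1` gives 25%

Compound 2 holds the lower of these two numbers. Compound 3 `Cc1ccc(S(=O)(=O)Oc2ccccc2/C=C(\C#N)C(=O)Nc2nnc(Cc3cccc4ccccc34)s2)cc1` differs from it in one place, naphthalen-1-yl in place of 4-methoxyphenyl on a saturated chain carbon bound to an aromatic carbon with naphthalen-1-yl in place of 4-methoxyphenyl on a saturated chain carbon bound to an aromatic carbon. For the measured compounds named here, only one measured step bears on this, a number 53 percentage points lower from compound 1 to compound 2 (beyond the scatter) with 4-methoxyphenyl in place of hydrogen. Going by the values given here, that large step replaces hydrogen, whereas here one aromatic group replaces another, and no measured pair shows such a swap. The estimated change in this assay is a number 5 percentage points higher from compound 2 to compound 3 (within the scatter) and no step beyond the scatter is expected. The expected value for compound 3 is 30% with an estimated range from 10% to 55% for now.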

Compound 3, percent growth inhibition at one concentration: 19%
The estimate for compound 3 lay 11 percentage points above the measured number; the measured number falls inside the stated range.
By their numbers in this assay, from the lowest: compounds 3 and 2 (each within the scatter of the next); then compound 1.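

In this assay the swap on a saturated chain carbon bound to an aromatic carbon gives a number 6 percentage points lower from compound 2 to compound 3 (within the scatter) and so does not separate naphthalen-1-yl from 4-methoxyphenyl. Replacing hydrogen at this place with a second aromatic group again gives a large loss, with a number 59 percentage points lower from compound 1 to compound 3 (beyond the scatter) as the step. Nothing measured here explains that loss.

Going by these compounds, whether the loss is confined to aromatic groups remains open. An amine, a carboxylic acid or a longer saturated chain at this place could test that.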